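Chloro in Place of Fluoro on the Anilino Ring

The source may report more compounds than this note shows. Statements on the series, on what has been measured and on what is new or still open speak of the compounds shown alone.

Compound 1 `O/N=C(/Nc1ccc(F)c(F)c1)c1ccc2occc2c1` and compound 2 `O/N=C(/Nc1ccc(Cl)c(F)c1)c1ccc2occc2c1` share a core and differ in one place: chloro in place of fluoro on an aromatic carbon. In an assay on tissue (HeLa cells) for inhibition of Indoleamine 2,3-dioxygenase 1 (Homo sapiens), read by spectrophotometry (a higher number here means a weaker inhibitor, a lower number a stronger inhibitor), compound 1 gives 14000 nM and compound 2 gives 10300 nM, so the change made a 1.4-fold lower number from compound 1 to compound 2 (0.13 log units; within the scatter). Compound 3 `O/N=C(/Nc1cccc(F)c1)c1ccc2oc(COCC3CC3)cc2c1` carries a different core; how the two cores differ is not broken down here. In this assay compound 3 gives 8000 nM, which lies close to the other two measured numbers.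

Compound 4 `O/N=C(/Nc1cccc(Cl)c1)c1ccc2oc(COCC3CC3)cc2c1` is not yet measured. It differs from compound 3 by chloro in place of fluoro on an aromatic carbon. For the measured compounds named here, this is the same kind of change as the one from compound 1 to compound 2, but not the same: there the place was ortho to a fluoro group and para to a large group, here it is meta to a large group.

Because the earlier change gave only a 1.4-fold lower number from compound 1 to compound 2 (0.13 log units; within the scatter), the step from compound 3 to compound 4 in this assay is expected to be small as well, about a 1.3-fold lower number from compound 3 to compound 4 (0.12 log units; within the scatter). Compound 4 is therefore estimated at 6000 nM, with a likely range from 2500 nM to 14000 nM.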

Compound 4, half-maximal inhibitory concentration: 17600 nM
Compound 4: middle estimate off by 2.9-fold (0.47 log units), on the low side; measured number above the stated range.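

In this assay, going from 3-fluorophenyl to 3-chlorophenyl gave a 2.2-fold higher number from compound 3 to compound 4 (0.34 log units; beyond the scatter), and this step does not match the earlier one, so the same swap did not behave alike on the two cores: the same change on two cores in this assay, a 1.4-fold lower number (0.13 log units; within the scatter) from compound 1 to compound 2 and a 2.2-fold higher number (0.34 log units; beyond the scatter) from compound 3 to compound 4, 3.0-fold (0.48 log units) apart, beyond the scatter of two such steps. For a newcomer, the lesson is that a swap that made no clear difference on the core of compound 1 cannot be assumed to do the same on the core of compound 3. These two pairs do not show why the steps differ, since the pairs differ both in the core and in the place of the swap, and two pairs set no general rule for the series.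

As far as these compounds go, it remains open whether the difference follows the core or the place, which a matched pair with the swap in the same place on both cores could help to settle. Also open, from the compounds shown here alone, is how bromo, methyl or nitrile in that place on the core of compound 3 would compare with fluoro and chloro.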